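The source may hold more compounds than are shown below. What is called first, only, known or untested is meant among the compounds shown, and "the series" means these compounds.

Compound 3 `O=C(O)CC[C@H](NC(=O)CN(c1nc(Cl)nc2[nH]cnc12)C1CC1)C(=O)O` gives 26.8% in a functional assay on the whole organism (Tail, strain ICR) with Mus musculus as the target, in the tail flick test, with a stated time of 30 min, at a dose of 25 umol/kg by the oral route (on this read-out lower numbers stand for a weaker effect and higher numbers for a stronger effect at the one dose given), the highest of the three numbers recorded, although all three lie within the usual scatter of one another: compound 2 `NCCCC[C@H](NC(=O)CN(c1nc(Cl)nc2[nH]cnc12)C1CC1)C(=O)OCc1ccccc1` gives 26.1% and compound 1 `CSCC[C@H](NC(=O)CN(c1nc(Cl)nc2[nH]cnc12)C1CC1)C(=O)OCc1ccccc1` gives 22.2%. Among the compounds with values here, the only measured step, a number 3.9 percentage points higher from compound 1 to compound 2 (within the scatter), swapped one side-chain group for another and moved the read-out by no more than the scatter. Compound 4 `NC(=O)C[C@H](NC(=O)CN(c1nc(Cl)nc2[nH]cnc12)C1CC1)C(=O)O` differs from compound 3 by carbamoyl in place of carboxymethyl on a saturated chain carbon, two bonds along the chain from an amide-type nitrogen and a carbonyl carbon. This is a different swap from the measured one, yet both exchange a side-chain group on a saturated chain carbon, and the measured one left the read-out where it was; so the step expected is a number 1.8 percentage points lower from compound 3 to compound 4 (within the scatter), none beyond the scatter. Compound 4 is therefore estimated at 25%, between 12% and 38%.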

Compound 4, a percentage reported as activity, at one dose (the size of the read-out at that dose, not a potency): 29.7%
Compound 4: the middle estimate sits 4.7 percentage points below what was measured; the measured number falls inside the stated range.
By their numbers in this assay, from the lowest: compounds 1, 2, 3 and 4 (each within the scatter of the next).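

In this assay, the change gives a step of a number 2.9 percentage points higher from compound 3 to compound 4 (within the scatter), so on this saturated chain carbon, two bonds along the chain from an amide-type nitrogen and a carbonyl carbon, carbamoyl stands in for carboxymethyl with no change beyond the scatter. The side-chain swap seen earlier now has a second example at a different place, and it too stays within the scatter. Nothing available bears on the cause of this result. Still open, from the compounds shown here alone, is whether an amine, a phenyl ring or a longer chain at this carbon would shift the read-out beyond the scatter.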